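Moving the ring nitrogen on the sulfonamide of compound 1

A few compounds are considered here, and "the series" means these few. Any claim that something is new, unique, unknown or untested is made for them only; others in the source may bear on it.

Compound 1 `Cn1nccc1-c1cc(C(F)(F)F)ccc1[C@H]1CCOc2cc(S(=O)(=O)Nc3ccncn3)ccc21` is the most soluble of the three compounds measured in a physicochemical assay for solubility (a higher number here means a more soluble compound, a lower number a less soluble compound), where compound 1 gives 1180000 nM. Its nearest neighbour is compound 2 `O=S(=O)(Nc1ccncn1)c1ccc2c(c1)OCC[C@@H]2c1ccc(C(F)(F)F)cc1-c1ccc(F)cn1`, which in this assay gives 181000 nM, a change of a 6.5-fold lower number from compound 1 to compound 2 (0.81 log units; beyond the scatter) brought about by putting 5-fluoropyridin-2-yl in place of 1-methyl-1H-pyrazol-5-yl on an aromatic carbon. Furthest from it is compound 3 `Cc1nc(-c2cc(C(F)(F)F)ccc2[C@@H]2CCOc3cc(S(=O)(=O)Nc4nccs4)ccc32)co1`, which in this assay gives 130000 nM.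

Compound 4 `Cn1nccc1-c1cc(C(F)(F)F)ccc1[C@H]1CCOc2cc(S(=O)(=O)Nc3cnccn3)ccc21` has not yet been measured. It differs from compound 1 in one place: pyrazin-2-yl in place of pyrimidin-4-yl on a sulfonamide nitrogen. Going by the values given here, the only measured step, from compound 1 to compound 2, touches a different part of the shared core, and compound 3 differs from compound 1 in more than one place, so no measured step bears directly on this change. The two values of compound 1 and compound 3 show that a different sulfonamide heteroaryl can coincide with a lower number, but that pair also carries a second change.

Among the compounds with values here, with no direct precedent, the step from compound 1 to compound 4 is expected to be a 1.5-fold lower number from compound 1 to compound 4 (0.17 log units; within the scatter), close to the scatter. Compound 4 is therefore estimated at 800000 nM in this assay, within a range from 250000 nM to 2500000 nM.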

Compound 4, solubility: 1170000 nM
Estimate against measurement, compound 4: 1.5-fold (0.17 log units) below; the measured number falls inside the stated range.
By their numbers in this assay, from the lowest: compounds 3 and 2 (each within the scatter of the next); then compounds 4 and 1 (each within the scatter of the next).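

In this assay, going by these compounds alone, the first reading at the sulfonamide nitrogen with nothing else altered is a 1.0-fold lower number from compound 1 to compound 4 (0.00 log units; within the scatter), whereas the earlier pair that pointed to this position also carried a second change. Pyrazin-2-yl and pyrimidin-4-yl, which match in heavy atoms and in counted donors and acceptors, therefore cannot be told apart here on the core of compound 1, while the step at the other place in the series, a 6.5-fold lower number from compound 1 to compound 2 (0.81 log units; beyond the scatter), lies beyond the scatter. No supporting measurement accompanies this result that would account for it.

Left open is whether a more different group on the sulfonamide nitrogen, such as pyridin-2-yl or a plain methyl, would also read like these two rings. Also open is whether the same exchange would read alike with 5-fluoropyridin-2-yl on the shared core, as in compound 2, given that it is shown here only with 1-methyl-1H-pyrazol-5-yl.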